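The source may report more compounds than this note shows. Statements on the series, on what has been measured and on what is new or still open speak of the compounds shown alone.

In an ADME assay on HepG2 2.2.15 cells (Homo sapiens) for cytotoxicity (on this read-out lower numbers stand for higher toxicity in this test and higher numbers for lower toxicity in this test), the measured compounds read:

- compound 1 `CC(=O)OCC(=O)OCCc1c(-c2ccccc2Cl)c2cc(Cl)ccc2[nH]c1=O` gives 100000 nM
- compound 2 `O=C(OCCc1c(-c2ccccc2Cl)c2cc(Cl)ccc2[nH]c1=O)C1CCCC1` gives 46000 nM
- compound 3 `CC(=O)N1CCC(C(=O)OCCc2c(-c3ccccc3Cl)c3cc(Cl)ccc3[nH]c2=O)CC1` gives 82000 nM

Compound 3 sits in the middle of these three numbers, but within the scatter of both neighbours, so that place means little. Compound 4 `O=C(OCCc1c(-c2ccccc2Cl)c2cc(Cl)ccc2[nH]c1=O)c1ccccc1` carries phenyl in place of 1-acetylpiperidin-4-yl on a carbonyl carbon. The closest guide is compound 2, whose cyclopentyl is also a ring of carbon only. The step of a 1.8-fold higher number from compound 2 to compound 3 (0.25 log units; within the scatter) stayed within the scatter, as did a 1.2-fold lower number from compound 1 to compound 3 (0.09 log units; within the scatter), while a 2.2-fold lower number from compound 1 to compound 2 (0.34 log units; beyond the scatter) was modest. In this assay only a small shift towards compound 2 is therefore expected. The expected step is a 1.6-fold lower number from compound 3 to compound 4 (0.21 log units; within the scatter) and should stay within the scatter. Compound 4 is estimated at 50000 nM (expected range 22000 nM to 100000 nM).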

Compound 4, half-maximal cytotoxic concentration: 43000 nM
Compound 4: middle estimate off by 1.2-fold (0.07 log units), on the high side; low and high end bracket the measured number.
By their numbers in this assay, from the lowest: compounds 4, 2, 3 and 1 (each within the scatter of the next, the first and the last beyond it).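

In this assay, phenyl on this carbonyl carbon cannot be told apart from cyclopentyl (a 1.1-fold lower number from compound 2 to compound 4 (0.03 log units; within the scatter)) or from 1-acetylpiperidin-4-yl (a 1.9-fold lower number from compound 3 to compound 4 (0.28 log units; within the scatter)). Only the change from acetoxymethyl passes the scatter (a 2.3-fold lower number from compound 1 to compound 4 (0.37 log units; beyond the scatter)), so both carbon-only rings now stand modestly apart from acetoxymethyl, while compound 3, with its nitrogen-containing ring, does not. No measurement available here gives a reason for this. Still open, from the compounds shown here alone, is how an amine or a carboxylic acid at this carbonyl carbon would read, and whether a longer chain would behave like acetoxymethyl.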